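Methyl on the hydroxy oxygen of compound 3

The source may report more compounds than this note shows. Statements on the series, on what has been measured and on what is new or still open speak of the compounds shown alone.

Compound 1 `COc1ccc(S(=O)(=O)Nc2ccc3oc(-c4ccc(NC(=O)c5cccc(C)c5[N+](=O)[O-])cc4)nc3c2)cc1` gives 2600 nM
Compound 2 `COc1ccc(S(=O)(=O)Nc2ccc3oc(-c4ccc(NC(=O)c5ccc(Cl)s5)cc4)nc3c2)cc1` gives 1100 nM
Compound 3 `O=C(Nc1ccc(Sc2nc3ccccc3s2)c(Cl)c1)c1cccc(Br)c1O` gives 9100 nM

In a functional assay on HCT-116 cells (Homo sapiens) for inhibition, read by crystal violet staining, with stated times of 72 h and 7 days (on this read-out higher numbers stand for an effect only at larger amounts of compound and lower numbers for an effect already at smaller amounts), compound 3 stands highest of the three (9100 nM), with compound 1 (2600 nM) and compound 2 (1100 nM) both lower beyond the scatter. Compound 4 `COc1c(Br)cccc1C(=O)Nc1ccc(Sc2nc3ccccc3s2)c(Cl)c1` differs from compound 3 in one place (methyl in place of hydrogen on an oxygen on an aromatic ring), reading as hydroxy to methoxy. For the measured compounds named here, no measured step touches this oxygen. Going by the values given here, the only step available (a 2.4-fold lower number from compound 1 to compound 2 (0.37 log units; beyond the scatter)) was modest and lies elsewhere on a different core, so it suggests a size but no direction. A modest rise is tentatively expected in this assay (a 2.2-fold higher number from compound 3 to compound 4 (0.34 log units; beyond the scatter)). Compound 4 is estimated at 20000 nM (expected range 6000 nM to 60000 nM).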

Compound 4, half-maximal effective concentration: 12000 nM
Compound 4: the middle estimate sits 1.7-fold (0.22 log units) above what was measured; the measured number falls inside the stated range.
By their numbers in this assay, from the lowest: compound 2; then compound 1; then compounds 3 and 4 (each within the scatter of the next).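

In this assay, methyl in place of hydrogen on this oxygen gives a 1.3-fold higher number from compound 3 to compound 4 (0.12 log units; within the scatter), so this read-out does not separate hydroxy from methoxy at this position. The hydrogen on this oxygen is therefore not required for the effect seen with compound 3. Nothing shown accounts for this result. As far as these compounds go, it remains open how a longer chain on this oxygen, or an amine in its place, would read. Also open, from the compounds shown here alone, is whether the same change would read alike on the core of compound 1.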